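The source may hold more compounds than are shown below. What is called first, only, known or untested is meant among the compounds shown, and "the series" means these compounds.

Measured in a functional assay on A549 cells (Homo sapiens) for inhibition; a lower number here means a stronger inhibitor, a higher number a weaker inhibitor:
- Compound 1 `O=S(=O)(c1ccccc1)n1ccc2cc(/C=C\c3ccc4ccccc4c3)ccc21`: > 5000 nM (a limit)
- Compound 2 `C(=C\c1ccc2[nH]ccc2c1)\c1ccc2ccccc2c1`: > 5000 nM (a limit)
- Compound 3 `Cn1ccc2cc(/C=C/c3ccc4ccccc4c3)ccc21`: 3530 nM

Among the measured compounds shown here, compound 3, at 3530 nM, is the only compound here with an actual number. The other two results are limits of the assay, so compound 3 cannot be ranked against them.

Compound 4 `Cn1ccc2cc(/C=C\c3ccc4ccccc4c3)ccc21` is its direct partner: the two compounds have the same atoms and bonds and differ only in configuration as drawn: 1 of 1 stereo elements differ; a double bond is drawn E in compound 3 and Z in compound 4. No atom is added or removed, so only the geometry as drawn changes.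

For the measured compounds named here, the only measured step, a step that the two limits leave unreadable from compound 1 to compound 2, concerns a different place in the molecule and has no readable size, so it gives no guide to this change. The remaining clue is the limit of > 5000 nM in this assay, at which 2 of the 3 values shown sit, which suggests that a result near or at that limit is a real possibility for compound 4. No direction can be argued from the data, so no shift beyond the scatter is expected in this assay. The expected change is a 1.4-fold lower number from compound 3 to compound 4 (0.15 log units; within the scatter), with wide uncertainty. For compound 4 the estimate is 2500 nM, with an expected range from 300 nM to 12000 nM.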

Compound 4, half-maximal inhibitory concentration: > 5000 nM
Compound 4: only a limit was reported; the forecaster's own chance of this, stated with the estimate: 35%; at least 2.0-fold (0.30 log units) between middle value and limit.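

This pair isolates the geometry of the double bond, and in this assay the change from E to Z is an at least 1.4-fold higher number from compound 3 to compound 4 (0.15 log units; that floor lies within the scatter). Among the compounds shown here, that floor lies within the scatter, so the result does not establish a real loss on going from the E to the Z form; it shows only that compound 4 has no number to set against compound 3. Compound 4 ends at a limit rather than a number, and results of that kind now dominate the set: the limit of > 5000 nM in this assay, at which 3 of the 4 values shown sit.

On these data alone, the steps from compound 1 and compound 2 to compound 4 run between two limits and cannot be read, so the effect of the group on the aromatic nitrogen remains unknown. Also open, as far as these compounds go, is how a longer chain or a chain ending in an amine at that nitrogen would read alongside the E double bond of compound 3.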